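The source may report more compounds than this note shows. Statements on the series, on what has been measured and on what is new or still open speak of the compounds shown alone.

Measured compounds:
- compound 1 `Nc1ccc(S(=O)(=O)Nc2ccnc3cc(C(F)(F)F)ccc23)cc1` gives 31000 nM in a functional assay on MDA-MB-231 cells (Homo sapiens) for antiproliferative activity, read by sulforhodamine B assay, with a stated time of 48 h; on this read-out higher numbers stand for weaker inhibition and lower numbers for stronger inhibition
- compound 2 `Cc1noc(NS(=O)(=O)c2ccc(N/C(S)=N\c3ccnc4cc(C(F)(F)F)ccc34)cc2)c1C` gives 27900 nM in this assay

The two values of compound 1 and compound 2 lie within the scatter of each other, so neither reading can be set apart from the other on this assay.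

Compound 3 `Cc1ccnc(NS(=O)(=O)c2ccc(N/C(S)=N\c3ccnc4cc(C(F)(F)F)ccc34)cc2)n1` differs from compound 2 by 4-methylpyrimidin-2-yl in place of 3,4-dimethyl-1,2-oxazol-5-yl on a sulfonamide nitrogen. Among the measured compounds shown here, no step between measured compounds covers this change, so the expected step is small, with no direction beyond the scatter. Compound 3 is therefore expected to give 25000 nM, within 8000 nM to 80000 nM, which means an estimated step of a 1.1-fold lower number from compound 2 to compound 3 (0.05 log units; within the scatter).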

Compound 3, half-maximal inhibitory concentration: 29800 nM
For compound 3 the middle estimate is 1.2-fold (0.08 log units) below the measured one, and the stated range covers the measured number.
By their numbers in this assay, from the lowest: compounds 2, 3 and 1 (each within the scatter of the next).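

On a sulfonamide nitrogen, 4-methylpyrimidin-2-yl in place of 3,4-dimethyl-1,2-oxazol-5-yl gives a 1.1-fold higher number from compound 2 to compound 3 (0.03 log units; within the scatter) in this assay. At this place, therefore, a six-membered and a five-membered aromatic ring, each with 2 hetero atoms, cannot be told apart on this read-out. No measurement at hand bears on this result.

Open, as far as these compounds go, is whether an unsubstituted phenyl, an acetyl group or a chain carrying a carboxylic acid on the same sulfonamide nitrogen would give a number beyond the scatter of compound 2 and compound 3.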